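The source may hold more compounds than are shown below. What is called first, only, known or untested is meant among the compounds shown, and "the series" means these compounds.

Working notes on the series. Three compounds sharing one core have been run in a toxicity assay on L02 cells (Homo sapiens) for cytotoxicity, read by MTT assay, with a stated time of 24 h; on this read-out higher numbers stand for lower toxicity in this test and lower numbers for higher toxicity in this test. Compound 1 `COc1cc(/C=C/C(=O)Nc2cccc(C)c2)ccc1OS(=O)(=O)c1ccc(Cl)cc1` gives 73500 nM. Compound 2 `COc1cc(/C=C/C(=O)Nc2ccc(I)cc2)ccc1OS(=O)(=O)c1ccc(Cl)cc1` gives 39400 nM. Compound 3 `CCOC(=O)/C=C/c1ccc(OS(=O)(=O)c2ccc(Cl)cc2)c(OC)c1` gives 137000 nM, the highest of the three numbers. Against its nearest neighbour the difference is a 1.9-fold higher number from compound 1 to compound 3 (0.27 log units; within the scatter), and against the furthest it is a 3.5-fold higher number from compound 2 to compound 3 (0.54 log units; beyond the scatter); the remaining pair shows a 1.9-fold lower number from compound 1 to compound 2 (0.27 log units; within the scatter).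

The compound to be measured next is compound 4 `COC(=O)/C=C/c1ccc(OS(=O)(=O)c2ccc(Cl)cc2)c(OC)c1`. Relative to compound 3 the change is hydrogen in place of methyl on a saturated chain carbon bound to an oxygen next to a carbonyl group. For the measured compounds named here, none of the measured steps touches this place: the two steps that reach compound 3 exchange a substituted amino group on the carbonyl carbon for ethoxy, and the third step exchanges one ring for another on the amide-type nitrogen. Trimming ethoxy to methoxy is a much smaller change than any of those exchanges, and the two steps that reach compound 3 already stay close to the scatter, so no step beyond the scatter is expected in this assay, in either direction.

Compound 4 is therefore expected to give about 130000 nM, with a range from 60000 nM to 280000 nM. The expected step is a 1.1-fold lower number from compound 3 to compound 4 (0.02 log units; within the scatter), which amounts to no change that this measurement could distinguish.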

Compound 4, half-maximal cytotoxic concentration: 99500 nM
Compound 4: middle estimate off by 1.3-fold (0.12 log units), on the high side; the range from low to high includes it.
By their numbers in this assay, from the lowest: compounds 2, 1, 4 and 3 (each within the scatter of the next, the first and the last beyond it).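

Cutting ethyl to methyl on the ester in this assay gives a step within the scatter (a 1.4-fold lower number from compound 3 to compound 4 (0.14 log units; within the scatter)), so compound 3 and compound 4 cannot be told apart, and this is the only step shown at this place on a saturated chain carbon bound to an oxygen next to a carbonyl group. With methoxy in place of ethoxy on the carbonyl carbon, the comparisons with the two amides read as they did before: the step from the 4-iodophenyl amide stays beyond the scatter and modest (a 2.5-fold higher number from compound 2 to compound 4 (0.40 log units; beyond the scatter)), while the step from the 3-methylphenyl amide stays within it (a 1.4-fold higher number from compound 1 to compound 4 (0.13 log units; within the scatter)), so compound 1 goes against any general separation of esters from amides. No measurement at hand bears on the reason for these numbers.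

The compounds shown leave open how a longer chain such as butoxy, or a carboxylic acid, on the carbonyl carbon would read in this assay. They also leave open whether the small ethyl to methyl step would hold on a core carrying a different group in place of the shared sulfonate.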